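Methoxy for trifluoromethyl across two related cores

A few compounds are considered here, and "the series" means these few. Any claim that something is new, unique, unknown or untested is made for them only; others in the source may bear on it.

Compound 1 `O=C1C=CCC(/C=C/c2ccc(C(F)(F)F)cc2)O1` and compound 2 `COc1ccc(/C=C/C2CC=CC(=O)O2)cc1` share one core, while compound 3 `O=C1C=CCC(/C=C/c2ccc(C(F)(F)F)cc2)N1` and compound 4 `COc1ccc(/C=C/C2CC=CC(=O)N2)cc1` share another; the difference between the two cores is not broken down here. In a functional assay on NCI-H460 cells (Homo sapiens) for inhibition, read by sulforhodamine B assay, with a stated time of 48 h (on this read-out higher numbers stand for weaker inhibition of growth and lower numbers for stronger inhibition of growth), compound 1 gives 477 uM, compound 2 gives 28.3 uM and compound 3 gives 150 uM. Within the first core the change methoxy in place of trifluoromethyl on an aromatic carbon gave a 17-fold lower number from compound 1 to compound 2 (1.23 log units; beyond the scatter). The same change is now made within the second core: methoxy in place of trifluoromethyl on an aromatic carbon, and compound 4 is not yet measured in this assay. Within the data shown here, a step of comparable size is expected, a 15-fold lower number from compound 3 to compound 4 (1.18 log units; beyond the scatter), because the one measured instance of this change gave a 17-fold lower number from compound 1 to compound 2 (1.23 log units; beyond the scatter). Among the measured compounds shown here, only a single pair supports this transfer, so the expected range is kept wide. Compound 4 is therefore estimated at 10 uM in this assay, with a range from 3 uM to 40 uM.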

Compound 4, concentration for growth inhibition (reported as GI): > 1090 uM
Compound 4: only a limit was reported; the forecaster's own chance of this, stated with the estimate: 5%; middle value at least 100-fold (2.03 log units) away from the limit.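

Methoxy in place of trifluoromethyl on an aromatic carbon does not carry over from one core to the other in this assay, and the two steps run in opposite directions: the same change on two cores in this assay, a 17-fold lower number (1.23 log units; beyond the scatter) from compound 1 to compound 2 and an at least 7.2-fold higher number (0.86 log units; beyond the scatter) from compound 3 to compound 4, at least 120-fold (2.08 log units) apart, beyond the scatter of two such steps. Compound 4 gives > 1090 uM, which is a limit of the assay and not a number. The step of an at least 7.2-fold higher number from compound 3 to compound 4 (0.86 log units; beyond the scatter) is therefore a minimum, and with one pair on each core the data show that the outcome of this change depends on the core, not which feature of the core decides it.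

The compounds shown leave open how a hydroxyl or a chlorine in the same place would behave on either core, and so whether the reversal is tied to methoxy and trifluoromethyl alone.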